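A Butyl Group on the Amide Nitrogen of Compound 1

A few compounds are considered here, and "the series" means these few. Any claim that something is new, unique, unknown or untested is made for them only; others in the source may bear on it.

Compound 1 `CCC1C(=O)N(C)c2cnc(-n3ccc4cc(C(N)=O)ccc43)nc2N1c1ccn(C)n1` was tested in a functional assay on NCI-H1975 cells (Homo sapiens) for antiproliferative activity, read by CCK-8 assay, with a stated time of 72 h (on this read-out lower numbers stand for stronger inhibition of growth and higher numbers for weaker inhibition of growth), and gave "not active" (no number reported), so no single number marks where compound 1 stands; only that qualitative outcome is known. Among the measured compounds shown here, a second measured compound, compound 2 `CC[C@@H]1C(=O)N(C)c2cnc(Nc3ccc(S(=O)(=O)NC4CCCC4)cc3)nc2N1C1CCCC1`, gave in this assay a value of 1710 nM; it shares the core with compound 1 but differs from it in several places at once, so its value shows only what that core can reach and says nothing about the single change followed here. Compound 3 `CCCCNC(=O)c1ccc2c(ccn2-c2ncc3c(n2)N(c2ccn(C)n2)C(CC)C(=O)N3C)c1` is the compound still to be measured. It differs from compound 1 in one place: butyl in place of hydrogen on an amide-type nitrogen. For the measured compounds named here, no step between measured compounds bears on this change. Starting from a result without a number, the expected step in this assay is uncertain; a modest shift toward measurable growth inhibition seems possible, but a result beyond the scatter in either direction cannot be excluded. Compound 3 is estimated to give 5000 nM, within 1500 nM to 20000 nM, with a real chance that only a limit is reported.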

Compound 3, concentration for 50% growth inhibition: 12000 nM
Compound 3: middle estimate off by 2.4-fold (0.38 log units), on the low side; measured number inside the range.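

In this assay, among the compounds shown here, compound 3 gives 12000 nM, while compound 1 gives "not active" (no number reported), with no number, so no step between these two compounds can be read. The compounds shown leave open how large a change butyl in place of the amide hydrogen brings. No measurement at hand bears on the reason for this result.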